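The source may hold more compounds than are shown below. What is called first, only, known or untested is meant among the compounds shown, and "the series" means these compounds.

In a functional assay on A549 cells (Homo sapiens) for inhibition, read by CCK-8 assay, with a stated time of 72 h, tested at 1 uM (on this read-out lower numbers stand for less inhibition of growth and higher numbers for more inhibition of growth at the one concentration tested), three compounds sharing one core have been measured. Compound 1 (`CN(C)C(=O)c1cc2cnc(Nc3ccc(NC(=O)C4(C(=O)Nc5ccc(Cl)c(C(F)(F)F)c5)CC4)cc3)nc2n1C1CCCC1`) gives 1.1%, compound 2 (`CN(C)C(=O)c1cc2cnc(Nc3ccc(NC(=O)C4(C(=O)Nc5cccc(C(F)(F)F)c5)CC4)cc3)nc2n1C1CCCC1`) gives 15.7%, and compound 3 (`COc1cccc(NC(=O)C2(C(=O)Nc3ccc(Nc4ncc5cc(C(=O)N(C)C)n(C6CCCC6)c5n4)cc3)CC2)c1`) gives 77.2%, the highest of the three and clear of both others beyond the scatter. The next compound to be read is compound 4 (`CN(C)C(=O)c1cc2cnc(Nc3ccc(NC(=O)C4(C(=O)Nc5ccccc5)CC4)cc3)nc2n1C1CCCC1`), which departs from compound 3 by hydrogen in place of methoxy on an aromatic carbon. For the measured compounds named here, three measured steps bear on this change. Hydrogen in place of chloro gave only a modest step, a number 14.6 percentage points higher from compound 1 to compound 2 (beyond the scatter). Methoxy in place of trifluoromethyl gave a large one, a number 61.5 percentage points higher from compound 2 to compound 3 (beyond the scatter), and the full aryl exchange gave a number 76.1 percentage points higher from compound 1 to compound 3 (beyond the scatter). Going by the values given here, no measured compound carries a bare phenyl, so these steps show only that the read-out moves widely with this ring's substituents. A sizeable fall from the top value is therefore expected, though with wide uncertainty. The estimated change is a number 29.2 percentage points lower from compound 3 to compound 4 (beyond the scatter). For compound 4 the expected value is 48%, within an estimated range of 15% to 80%.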

Compound 4, percent growth inhibition at one concentration: 75%
Beside the measured number, compound 4's estimate is 27 percentage points below it; the measured number falls inside the stated range.
By their numbers in this assay, from the lowest: compound 1; then compound 2; then compounds 4 and 3 (each within the scatter of the next).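

In this assay, hydrogen in place of methoxy leaves the read-out within the scatter (a number 2.2 percentage points lower from compound 3 to compound 4 (within the scatter)), so the high growth inhibition seen with compound 3 does not require the methoxy, and the unsubstituted phenyl does as well. The large steps (a number 59.3 percentage points higher from compound 2 to compound 4 (beyond the scatter); a number 73.9 percentage points higher from compound 1 to compound 4 (beyond the scatter)) show that among these four compounds the low values belong to the two that carry trifluoromethyl, compound 1 and compound 2, with no exception. Nothing measured here explains this difference.

Still open, as far as these compounds go, is whether an amine, a hydroxy group or a carboxylic acid at this place on the ring would keep the read-out near that of compound 4. A reading at one concentration also leaves open whether compound 3 and compound 4 would separate across a range of concentrations.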